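The compounds below may be only part of what the source reports. "The series", "measured", "known", "first", "only" and "open" are said of these compounds alone.

Compound 1 `NS(=O)(=O)c1ccc(/N=C2\NC(=O)/C(=C3/C(=O)Nc4ccc(F)cc43)S2)cc1`: 20500 nM
Compound 2 `NS(=O)(=O)c1ccc(/N=C2\NC(=O)/C(=C3/C(=O)Nc4ccc(Br)cc43)S2)cc1`: 11300 nM
Compound 3 `NS(=O)(=O)c1ccc(/N=C2\NC(=O)/C(=C3/C(=O)Nc4ccc([N+](=O)[O-])cc43)S2)cc1`: > 200000 nM

The three compounds share one core and differ only in the group on the aromatic ring of that core. All were tested in a functional assay on MCF7 cells (Homo sapiens) for antiproliferative activity, read by MTT assay; a higher number here means a weaker inhibitor, a lower number a stronger inhibitor. Compound 1 gives 20500 nM and compound 2 gives 11300 nM, with the step of a 1.8-fold lower number from compound 1 to compound 2 (0.26 log units; within the scatter). Compound 3 stands apart: in this assay compound 3 returns only a limit, > 200000 nM, not a measured number. The steps of an at least 9.7-fold higher number from compound 1 to compound 3 (0.98 log units; beyond the scatter) and an at least 17-fold higher number from compound 2 to compound 3 (1.24 log units; beyond the scatter) make compound 3 the weakest of the three.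

Compound 4 `NS(=O)(=O)c1cccc(/N=C2\NC(=O)/C(=C3/C(=O)Nc4ccc([N+](=O)[O-])cc43)S2)c1` keeps the whole of compound 3 except for one change: 3-sulfamoylphenyl in place of 4-sulfamoylphenyl on a double-bonded nitrogen. Within the data shown here, none of the measured steps touches this part of the molecule; all three concern the group on the other ring, so they offer no direct guide to the direction or size of this step. Because compound 3 already sits at the limit of > 200000 nM in this assay, at which 1 of the 3 values shown sits, compound 4 is expected to remain very weak, and a limit rather than a number is quite possible again. Compound 4 is estimated at 200000 nM, within 60000 nM to 600000 nM. The expected step is a number no higher from compound 3 to compound 4 (the limit leaves the size open), which is to say nothing beyond the scatter.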

Compound 4, half-maximal inhibitory concentration: > 200000 nM
Compound 4 ended at the assay's limit; the forecaster's own chance of this, stated with the estimate: 60%; the middle value sits exactly at the limit.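

In this assay compound 4 returns > 200000 nM, a limit and not a number. The step from compound 3 to compound 4 therefore cannot be read: the limit of > 200000 nM in this assay, at which 2 of the 4 values shown sit.

Still open, from the compounds shown here alone, is whether 3-sulfamoylphenyl in place of 4-sulfamoylphenyl changes activity at all, with nitro or with the bromo or fluoro groups of compound 2 and compound 1.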